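Cyclopropyl for 4-methoxybenzyl on the amide nitrogen

A few compounds are considered here, and "the series" means these few. Any claim that something is new, unique, unknown or untested is made for them only; others in the source may bear on it.

Values in a functional assay on A549 cells (Homo sapiens) for inhibition, read by sulforhodamine B assay, with a stated time of 72 h (a lower number here means a stronger inhibitor, a higher number a weaker inhibitor), are these:
- compound 1 `Nc1sc(-c2ccc(Cl)cc2)c(-c2ccc(Cl)cc2)c1C(=O)NC1CCC1` gives 12500 nM
- compound 2 `COc1ccc(CNC(=O)c2c(N)sc(-c3ccc(Cl)cc3)c2-c2ccc(Cl)cc2)cc1` gives 18200 nM

Within the data shown here, on these numbers compound 2 has only one neighbour, compound 1, and the two values lie within the scatter of each other, so neither ranks ahead. The next compound, compound 3 `Nc1sc(-c2ccc(Cl)cc2)c(-c2ccc(Cl)cc2)c1C(=O)NC1CC1`, carries cyclopropyl in place of 4-methoxybenzyl on an amide-type nitrogen, a change counted as cyclopropyl in place of 4-methoxybenzyl on an amide-type nitrogen in full. Among the measured compounds shown here, one measured step bears on it. For the measured compounds named here, putting 4-methoxybenzyl in place of cyclobutyl on the same nitrogen gave a 1.5-fold higher number from compound 1 to compound 2 (0.16 log units; within the scatter), so the only exchange seen so far at this nitrogen stays inside the scatter. Cyclopropyl itself has no measurement yet, and two compounds are a thin basis. No step beyond the scatter is therefore expected in this assay, in either direction. The estimated step is a 1.3-fold lower number from compound 2 to compound 3 (0.11 log units; within the scatter) in size. For compound 3 the expected value is 14000 nM, with an estimated range from 7000 nM to 28000 nM.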

Compound 3, half-maximal inhibitory concentration: 1950 nM
Beside the measured number, compound 3's estimate is 7.2-fold (0.86 log units) above it; the whole stated range lies above it.
By their numbers in this assay, from the lowest: compound 3; then compounds 1 and 2 (each within the scatter of the next).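

In this assay the amide-type nitrogen proves sensitive to its substituent, which the first two compounds did not show: cyclopropyl in place of 4-methoxybenzyl gives a 9.3-fold lower number from compound 2 to compound 3 (0.97 log units; beyond the scatter), and cyclopropyl in place of cyclobutyl gives a 6.4-fold lower number from compound 1 to compound 3 (0.81 log units; beyond the scatter). Compound 1 and compound 2 lie within the scatter of each other, so the lower number belongs to cyclopropyl among these three groups and does not follow from the loss of 4-methoxybenzyl alone, since cyclobutyl, which also lacks it, stays with compound 2. No measurement available here speaks to the reason for this difference.

As far as these compounds go, whether the lower number is confined to the three-membered ring or also appears with an open chain such as ethyl or isopropyl, or with a plain primary amide, remains open. All three compounds share the same core and differ only at this nitrogen, so they also leave open how the cyclopropyl amide would read if the amide were replaced by a carboxylic acid or if the free amine on the core were acylated.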